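The source may report more compounds than this note shows. Statements on the series, on what has been measured and on what is new or still open speak of the compounds shown alone.

In a functional assay with Oryctolagus cuniculus as the target (on this read-out lower numbers stand for stronger inhibition and higher numbers for weaker inhibition), compound 1 (`CNC(=N)Nc1nc(-c2ccc(OC)cc2)c(-c2ccc(OC)cc2)s1`) gives 62 nM. Compound 2 (`CC/N=C(/N)Nc1nc(-c2ccc(OC)cc2)c(-c2ccc(OC)cc2)s1`) gives only a limit, > 100 nM, and so stands at the limit of > 100 nM in this assay, at which 2 of the 3 values shown sit. Compound 3 (`COc1ccc(-c2nc(/N=C(\N)NC(C)C)sc2-c2ccc(OC)cc2)cc1`) also gives only a limit, > 100 nM. Compound 4 (`C/N=C(/NC)Nc1nc(-c2ccc(OC)cc2)c(-c2ccc(OC)cc2)s1`) departs from compound 2 as follows: a group of 5 heavy atoms (3 carbon, 2 nitrogen; no ring) in place of a group of 5 heavy atoms (3 carbon, 2 nitrogen; no ring), on a nitrogen on an aromatic ring. The two have the same atoms, joined differently. Going by the values given here, two measured steps bear on this change, an at least 1.6-fold higher number from compound 1 to compound 2 (0.20 log units; that floor lies within the scatter) and an at least 1.6-fold higher number from compound 1 to compound 3 (0.20 log units; that floor lies within the scatter), and each gives only a floor on its size. Neither points to a direction for this rearrangement, so no step beyond the scatter is expected in this assay. The expected step is a step that the limit leaves unreadable from compound 2 to compound 4. Compound 4 is estimated at 150 nM, within an expected range of 60 nM to 400 nM.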

Compound 4, half-maximal inhibitory concentration: 970 nM
Compound 4: the middle estimate sits 6.5-fold (0.81 log units) below what was measured; measured number outside the range, above it.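

In this assay, the step at this nitrogen on an aromatic ring now has a measured size rather than only a floor: a 16-fold higher number from compound 1 to compound 4 (1.19 log units; beyond the scatter). With one more carbon in the group than compound 1, compound 4 thus shows a loss beyond the scatter. Compound 2 still has only a limit: the limit of > 100 nM in this assay, at which 2 of the 4 values shown sit.

As far as these compounds go, the steps from compound 2 and compound 3 to compound 4 cannot be read, so the effect of the rearrangement itself stays open. Also open, from the compounds shown here alone, is whether a cyclopropyl group or a longer chain in this place would stay close to compound 1, at 62 nM.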